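This account rests on a few compounds, and the source may have more. Where it says the series, first, only, none or still open, it means among the compounds named here.

Compound 1 `O=C(Nc1nn(-c2ccccc2)c(=O)c2ccccc12)c1ccccc1` is the starting point. Within the data shown here, in an assay on CHO cells for displacement of a labelled ligand from adenosine receptor A1 (Homo sapiens), tested at 10 uM (a lower number here means less inhibition, a higher number more inhibition at the concentration tested (going by the name of the read-out)), compound 1 gives 44%, the highest of the three numbers measured so far. Two related compounds, in which an amino group replaces the phenyl on the carbonyl carbon, were also measured. Compound 2 `O=C(Nc1ccccc1Cl)Nc1nn(-c2ccccc2)c(=O)c2ccccc12` gives 0% in this assay, and compound 3 `O=C(NCc1ccccc1)Nc1nn(-c2ccccc2)c(=O)c2ccccc12` gives 20%. Both steps away from compound 1 lowered the read-out beyond the scatter: a number 44 percentage points lower from compound 1 to compound 2 (beyond the scatter), and a number 24 percentage points lower from compound 1 to compound 3 (beyond the scatter). Between the two amino-substituted compounds, a number 20 percentage points higher from compound 2 to compound 3 (beyond the scatter).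

Compound 4 `COc1ccccc1NC(=O)Nc1nn(-c2ccccc2)c(=O)c2ccccc12` has not yet been measured. It differs from compound 1 in one place: (2-methoxyphenyl)amino in place of phenyl on a carbonyl carbon. Among the measured compounds shown here, of the measured steps, the one to compound 2 bears on this most directly, since a (2-chlorophenyl)amino group there stands where a (2-methoxyphenyl)amino group stands in compound 4, and the benzylamino of compound 3 serves as a second, milder reference. Both point downward, and the step to compound 2 was the large one. The expectation for compound 4 is therefore a large fall, about a number 36 percentage points lower from compound 1 to compound 4 (beyond the scatter). Compound 4 is estimated at 8%, with a likely range from 0% to 30%.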

Compound 4, a percentage reported as inhibition, at one concentration (the size of the read-out at that concentration, not a potency): 0%
Compound 4: the middle estimate sits 8 percentage points above what was measured; measured number inside the range.
By their numbers in this assay, from the lowest: compounds 2 and 4 (each within the scatter of the next); then compound 3; then compound 1.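

The fall on the carbonyl carbon is not confined to the (2-chlorophenyl)amino group of compound 2, since in this assay the (2-methoxyphenyl)amino group also brings a large drop (a number 44 percentage points lower from compound 1 to compound 4 (beyond the scatter)). Methoxy in place of chloro on the aromatic carbon leaves no readable difference (no change at the digits printed from compound 2 to compound 4 (within the scatter)), although compound 2 already gives 0%, so this pair has no room to show any further fall. On the amide-type nitrogen, 2-methoxyphenyl now joins 2-chlorophenyl in reading lower than benzyl (a number 20 percentage points lower from compound 3 to compound 4 (beyond the scatter)), a pattern that rests on only these three compounds and that none of them goes against.

Nothing available explains these differences in the read-out. The compounds shown leave open whether the loss follows the amino link itself or the groups carried on it, a question that an unsubstituted phenylamino or a small alkylamino group such as methylamino on the carbonyl carbon could help to separate.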